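This account rests on a few compounds, and the source may have more. Where it says the series, first, only, none or still open, it means among the compounds named here.

Measured in an ADME assay on HepG2 2.2.15 cells (Homo sapiens) for cytotoxicity; on this read-out lower numbers stand for higher toxicity in this test and higher numbers for lower toxicity in this test:
- Compound 1 `CC(C)C(=O)OCCc1c(-c2ccccc2Cl)c2cc(Cl)ccc2[nH]c1=O`: 62000 nM
- Compound 2 `O=C(CN1C(=O)c2ccccc2C1=O)OCCc1c(-c2ccccc2Cl)c2cc(Cl)ccc2[nH]c1=O`: 960000 nM

Compound 2 has the higher of the two numbers, so it looks the less toxic in this small set. Compound 3 `O=C(/C=C/c1cccc(F)c1)OCCc1c(-c2ccccc2Cl)c2cc(Cl)ccc2[nH]c1=O` differs from it by a group of 9 heavy atoms (8 carbon, 1 fluorine; one six-membered aromatic ring of carbon only) in place of a group of 12 heavy atoms (9 carbon, 1 nitrogen, 2 oxygen; one five-membered non-aromatic ring with 1 hetero atom, one six-membered aromatic ring of carbon only), on a carbonyl carbon. The group that enters is 2-(3-fluorophenyl)ethenyl, on a carbonyl carbon.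

For the measured compounds named here, only one measured step bears on this swap: a 15-fold higher number from compound 1 to compound 2 (1.19 log units; beyond the scatter). That large step came when the group compound 3 lacks was put on the same carbonyl carbon. Going by the values given here, no measured compound carries 2-(3-fluorophenyl)ethenyl, so its behaviour in this assay is unknown. A partial fall towards compound 1 at 62000 nM seems most likely, and the size is uncertain.

The expected change is an 8.0-fold lower number from compound 2 to compound 3 (0.90 log units; beyond the scatter). For compound 3 the estimated value is 120000 nM, with an expected range of 30000 nM to 480000 nM.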

Compound 3, half-maximal cytotoxic concentration: > 1600000 nM
Compound 3: no number, only a limit; the forecaster's own chance of this, stated with the estimate: 10%; middle value at least 13-fold (1.12 log units) away from the limit.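

Compound 3 is recorded in this assay at > 1600000 nM, which is a limit of the assay and not a number: the limit of > 1600000 nM in this assay, at which 1 of the 3 values shown sits. Measured against the isopropyl ester, the change gives an at least 25-fold higher number from compound 1 to compound 3 (1.41 log units; beyond the scatter), so a high number on this carbonyl carbon does not need the nitrogen or the oxygens of the group in compound 2, as 2-(3-fluorophenyl)ethenyl has none of them. The swap itself gives an at least 1.6-fold higher number from compound 2 to compound 3 (0.22 log units; that floor lies within the scatter), so the two large groups cannot be ranked in this assay.

Going by these compounds, it remains open whether the fluorine matters, which 2-phenylethenyl without it would test. Also open, on these data alone, is how a small group such as methyl, or a chain ending in an amine, would behave on the same carbonyl carbon.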